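From the acetal of compound 2 to an aldehyde

The source may report more compounds than this note shows. Statements on the series, on what has been measured and on what is new or still open speak of the compounds shown alone.

Compound 1, `Cn1c(Cc2nn(C)c(=O)c3ccccc23)nnc1SCC(=O)Nc1ccc(Cl)cc1Cl`, gives 21100 nM in an assay on 32D cells for inhibition of interleukin-15 (Mus musculus), read by resazurin assay, with stated times of 30 min and 2.5 days, in the presence of a further agent that is not named here; on this read-out lower numbers stand for stronger inhibition and higher numbers for weaker inhibition.
Compound 2, `CCOC(CCn1c(Cc2nn(C)c(=O)c3ccccc23)nnc1SCC(=O)Nc1ccc(Cl)cc1Cl)OCC`, gives only a limit of the assay, > 30000 nM, in this assay.

Compound 2 therefore has no number of its own in this assay, only the limit noted in the limit of > 30000 nM in this assay, at which 1 of the 2 values shown sits. Among the measured compounds shown here, the single measured step that touches it, an at least 1.4-fold higher number from compound 1 to compound 2 (0.15 log units; that floor lies within the scatter), lies within the usual scatter, so it shows no clear movement. Compound 3, `Cn1nc(Cc2nnc(SCC(=O)Nc3ccc(Cl)cc3Cl)n2CCC=O)c2ccccc2c1=O`, carries a change made on the chain of compound 2: formyl in place of diethoxymethyl on a saturated chain carbon, two bonds along the chain from an aromatic nitrogen. For the measured compounds named here, no measured step covers this change itself, and the one step available stays within the scatter. The step from compound 2 to compound 3 in this assay is thus expected to be an at least 1.0-fold lower number from compound 2 to compound 3 (0.02 log units; that floor lies within the scatter), with a real chance that the assay again reports only a limit. Compound 3 is expected to give about 28000 nM, between 9000 nM and 60000 nM.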

Compound 3, half-maximal inhibitory concentration: 6400 nM
Compound 3: middle estimate off by 4.4-fold (0.64 log units), on the high side; measured number below the stated range.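

Through this assay, the end of the chain now proves to matter at this position: formyl in place of diethoxymethyl gives an at least 4.6-fold lower number from compound 2 to compound 3 (0.67 log units; beyond the scatter). The earlier step showed no clear movement, whereas compound 3 also improves on compound 1, with a 3.3-fold lower number from compound 1 to compound 3 (0.52 log units; beyond the scatter), so a chain here can bring stronger inhibition rather than merely leave it unchanged. The first of these steps gives only a minimum size, since compound 2 has no number of its own: the limit of > 30000 nM in this assay, at which 1 of the 3 values shown sits.

Going by these compounds, it stays open whether the formyl group itself counts or simply the removal of the larger diethoxymethyl end, a question that a carboxylic acid, an alcohol or an amine at the same chain end could help to settle. A longer chain ending in formyl would show whether the chain length matters too.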